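The source may hold more compounds than are shown below. What is called first, only, known or untested is meant among the compounds shown, and "the series" means these compounds.

Measured so far in a functional assay on HeLa cells (Homo sapiens) for cytotoxicity, read by MTT assay; on this read-out higher numbers stand for weaker inhibition and lower numbers for stronger inhibition:
- compound 1 `CCCCC(CC(=O)O[C@H](CC=C(C)C)C1=CC(=O)c2c(O)ccc(O)c2C1=O)OC(C)=O` gives 73500 nM
- compound 2 `CC(C)=CC[C@@H](OCC(C)O)C1=CC(=O)c2c(O)ccc(O)c2C1=O` gives 24700 nM

Of these two, compound 2 has the lower number and so the stronger inhibition, and its gap to compound 1 lies beyond the usual scatter. Compound 3 `CC(C)=CC[C@@H](OC(=O)C1CCCO1)C1=CC(=O)c2c(O)ccc(O)c2C1=O` keeps the shared core but changes one group of compound 2: (oxolan-2-yl)carbonyl stands in place of 2-hydroxypropyl on an oxygen on a saturated carbon (oxolan-2-yl)carbonyl in place of 2-hydroxypropyl on an oxygen on a saturated carbon and this is the whole difference. For the measured compounds named here, no measured pair shows this change, so any forecast is loose. Compound 1 also carries a carbonyl on that oxygen and gives the higher number (73500 nM), which suggests a slight lean upward. The expected step of a 1.4-fold higher number from compound 2 to compound 3 (0.15 log units; within the scatter) should therefore stay within the scatter in this assay and is only an estimate. For compound 3 the expected value is 35000 nM with a wide estimated range (from 10000 nM to 100000 nM).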

Compound 3, half-maximal inhibitory concentration: 17000 nM
Beside the measured number, compound 3's estimate is 2.1-fold (0.31 log units) above it; the measured number falls inside the stated range.
By their numbers in this assay, from the lowest: compounds 3 and 2 (each within the scatter of the next); then compound 1.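

In this assay, putting (oxolan-2-yl)carbonyl in place of 2-hydroxypropyl on this oxygen leaves the result within the scatter (a 1.5-fold lower number from compound 2 to compound 3 (0.16 log units; within the scatter)), so across this one pair, the hydroxyl of 2-hydroxypropyl is not needed to keep the number where it stands. A carbonyl on this oxygen also does not by itself go with the weaker inhibition of compound 1: with the carbonyl kept, oxolan-2-yl in place of 2-acetoxyhexyl gives a modest step beyond the scatter (a 4.3-fold lower number from compound 1 to compound 3 (0.64 log units; beyond the scatter)), which points to the group on the far side of the carbonyl. No independent data explain either step.

The compounds shown leave open whether the ring oxygen of oxolan-2-yl matters, which a cyclopentyl group on the same carbonyl would test. On these data alone, how an amine or a carboxylic acid would behave on this oxygen also remains open.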